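Triazole amide series: methoxy for fluoro on the benzyl

The source may hold more compounds than are shown below. What is called first, only, known or untested is meant among the compounds shown, and "the series" means these compounds.

Measured so far in a functional assay on HeLa cells (Homo sapiens) for antiproliferative activity, read by sulforhodamine B assay, with a stated time of 48 h; on this read-out higher numbers stand for weaker inhibition of growth and lower numbers for stronger inhibition of growth:
compound 1 `O=C(NCc1cn(Cc2ccc(F)cc2)nn1)c1cn(-c2ccccc2)nc1-c1ccccc1` — 1600 nM
compound 2 `COc1ccc(Cn2cc(CNC(=O)c3cn(-c4ccccc4)nc3-c3ccc(F)cc3)nn2)cc1` — 870 nM
compound 3 `O=C(NCc1cn(Cc2ccc(F)cc2)nn1)c1cn(-c2ccccc2)nc1-c1ccc(Cl)cc1` — 2800 nM

Compound 3 gives the highest number of the three. Its nearest neighbour is compound 1, the step of a 1.8-fold higher number from compound 1 to compound 3 (0.24 log units; within the scatter) lying within the scatter; compound 2 is the furthest, its number being below that of compound 3 by more than the scatter.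

Compound 4 `COc1ccc(Cn2cc(CNC(=O)c3cn(-c4ccccc4)nc3-c3ccc(Cl)cc3)nn2)cc1` is not yet measured. It differs from compound 3 by methoxy in place of fluoro on an aromatic carbon. Going by the values given here, no single measured step covers this change: the only one-place step recorded, from compound 1 to compound 3, concerns the chloro on the other ring and stays within the scatter. Compound 2, which already carries the 4-methoxybenzyl, gives 870 nM, but it also differs from compound 3 on the phenyl ring, so its value cannot be read as the effect of the benzyl change alone. A step of a 2.0-fold lower number from compound 3 to compound 4 (0.30 log units; within the scatter) is therefore expected, the number of compound 4 being estimated at 1400 nM, with a range from 450 nM to 4500 nM.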

Compound 4, concentration for 50% growth inhibition: 1400 nM
Estimate against measurement, compound 4: no gap at the digits printed; the measured number falls inside the stated range.
By their numbers in this assay, from the lowest: compounds 2, 4, 1 and 3 (each within the scatter of the next, the first and the last beyond it).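

In this assay, going by these compounds alone, the change from 4-fluorobenzyl to 4-methoxybenzyl, with the chloro on the other aromatic ring unchanged, is a 2.0-fold lower number from compound 3 to compound 4 (0.30 log units; within the scatter) and gives the direct reading of this swap that the earlier compounds could not give. With the 4-methoxybenzyl kept, chloro in place of fluoro on the other aromatic ring is a 1.6-fold higher number from compound 2 to compound 4 (0.21 log units; within the scatter) so neither single change among these compounds moves the number beyond the scatter. No measurement on hand accounts for either step.

The compounds shown leave open whether an amine or a carboxylic acid in place of the methoxy would give a step beyond the scatter. Going by these compounds, whether a longer alkoxy chain at this position would do so also remains open.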